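The source may hold more compounds than are shown below. What is called first, only, known or untested is meant among the compounds shown, and "the series" means these compounds.

Measured compounds:
compound 1 `Cc1cc(S(=O)(=O)/N=C(\N)N/N=C/C#Cc2ccccc2)c(SCc2ccccc2)cc1Cl`, 24000 nM
compound 2 `Cc1cccc(CSc2cc(Cl)c(C)cc2S(=O)(=O)/N=C(\N)N/N=C/C#Cc2ccccc2)c1`, 16000 nM
compound 3 `C/C(C#Cc1ccccc1)=N\N/C(N)=N/S(=O)(=O)c1cc(C)c(Cl)cc1SCc1cccc(C)c1`, 130000 nM

In a functional assay on MCF7 cells (Homo sapiens) for antiproliferative activity, read by MTT assay, with a stated time of 72 h (on this read-out lower numbers stand for stronger inhibition and higher numbers for weaker inhibition), compound 3 gives the highest number of the three; compound 1 sits nearer to it and compound 2 is the furthest, both gaps beyond the scatter. The two steps measured so far read as follows. From compound 1 to compound 2, methyl in place of hydrogen on an aromatic carbon, a 1.5-fold lower number from compound 1 to compound 2 (0.18 log units; within the scatter). From compound 2 to compound 3, the change on the amine nitrogen, an 8.1-fold higher number from compound 2 to compound 3 (0.91 log units; beyond the scatter).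

Compound 4 `C/C(C#Cc1ccccc1)=N\N/C(N)=N/S(=O)(=O)c1cc(C)c(Cl)cc1SCc1cccc(Cl)c1` differs from compound 3 by chloro in place of methyl on an aromatic carbon, that is, (3-methylbenzyl)sulfanyl becomes (3-chlorobenzyl)sulfanyl. Among the compounds with values here, no measured pair exchanges methyl for chloro, so nothing bears on this step directly. Within the data shown here, the only step touching this ring, a 1.5-fold lower number from compound 1 to compound 2 (0.18 log units; within the scatter), stayed within the scatter, and this is the sole guide. A step of no more than the scatter is therefore expected in this assay, in no clear direction.

Compound 4 is estimated at 120000 nM, with a range of 50000 nM to 300000 nM. This estimate corresponds to an expected step of a 1.1-fold lower number from compound 3 to compound 4 (0.03 log units; within the scatter).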

Compound 4, half-maximal inhibitory concentration: 80000 nM
Estimate against measurement, compound 4: 1.5-fold (0.18 log units) above, and the stated range covers the measured number.
By their numbers in this assay, from the lowest: compounds 2 and 1 (each within the scatter of the next); then compounds 4 and 3 (each within the scatter of the next).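

In this assay, within the data shown here, the exchange of methyl for chloro, on an aromatic carbon meta to a large group, gives a 1.6-fold lower number from compound 3 to compound 4 (0.21 log units; within the scatter) and is the first exchange of one substituent for another at this place. Among these compounds, with a 1.5-fold lower number from compound 1 to compound 2 (0.18 log units; within the scatter) as the earlier hydrogen-to-methyl step, two changes at this place on two different backgrounds now stay within the scatter, while the one step beyond it in this set remains an 8.1-fold higher number from compound 2 to compound 3 (0.91 log units; beyond the scatter) on the amine nitrogen, so (3-chlorobenzyl)sulfanyl does not recover the number lost at that step. No supporting data are available to account for how either methyl or chloro at this place acts on the read-out.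

Whether this place stays as flat with a carboxylic acid, an amine or a longer chain in place of chloro remains open, since methyl and chloro are the only substituents shown here. Also open is whether chloro reads the same on the background of compound 2, where the change on the amine nitrogen is absent, as no pair shown tests that.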